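Aniline variation on the shared core: cytotoxicity notes

The source may report more compounds than this note shows. Statements on the series, on what has been measured and on what is new or still open speak of the compounds shown alone.

Measured compounds:
compound 1 `COc1ccccc1Nc1nc(SCc2ccc(C(F)(F)F)cc2)nc2ccccc12`: > 50000 nM in a functional assay on MGC-803 cells (Homo sapiens) for cytotoxicity, read by MTT assay, with a stated time of 72 h; on this read-out higher numbers stand for weaker inhibition and lower numbers for stronger inhibition
compound 2 `FC(F)(F)c1ccc(CSc2nc(Nc3cccc(Cl)c3)c3ccccc3n2)cc1`: 14600 nM
compound 3 `Cc1ccc(Nc2nc(SCc3ccc(C(F)(F)F)cc3)nc3ccccc23)cc1`: 36100 nM

All three share one core and differ only in the aryl group on the nitrogen on the aromatic ring. The value of compound 1 is a limit of the assay and not a number. Among the two numbers, compound 3 gives the highest; the step between them reads a 2.5-fold higher number from compound 2 to compound 3 (0.39 log units; beyond the scatter). Against the limit, the steps read an at least 3.4-fold lower number from compound 1 to compound 2 (0.53 log units; beyond the scatter) and an at least 1.3-fold lower number from compound 1 to compound 3 (0.14 log units; that floor lies within the scatter).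

Compound 4 `COc1ccc(Nc2nc(SCc3ccc(C(F)(F)F)cc3)nc3ccccc23)cc1OC` is not yet measured. Its change from compound 3 is 3,4-dimethoxyphenyl in place of 4-methylphenyl on a nitrogen on an aromatic ring. Among the measured compounds shown here, no measured step puts two methoxy groups on this aryl ring. For the measured compounds named here, what bears on it is an at least 1.3-fold lower number from compound 1 to compound 3 (0.14 log units; that floor lies within the scatter), where the one compound carrying a methoxy group sits at the limit of > 50000 nM in this assay, at which 1 of the 3 values shown sits, and a 2.5-fold higher number from compound 2 to compound 3 (0.39 log units; beyond the scatter), which shows how little the aryl group moves the number. For compound 4 no step beyond the scatter is expected, with the risk lying toward a limit; the estimate is a 1.1-fold higher number from compound 3 to compound 4 (0.02 log units; within the scatter). Compound 4 is therefore estimated at 38000 nM (range 13000 nM to 110000 nM).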

Compound 4, half-maximal inhibitory concentration: 16300 nM
For compound 4 the middle estimate is 2.3-fold (0.37 log units) above the measured one; the measured number falls inside the stated range.
By their numbers in this assay, from the lowest: compounds 2 and 4 (each within the scatter of the next); then compound 3. At a limit, above all of these: compound 1.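

In this assay, a methoxy-bearing aryl group on this nitrogen does not have to sit at the weak end of the series: 3,4-dimethoxyphenyl in place of 4-methylphenyl gives a 2.2-fold lower number from compound 3 to compound 4 (0.35 log units; beyond the scatter). The 3,4-dimethoxyphenyl and 3-chlorophenyl groups read alike here, with a 1.1-fold higher number from compound 2 to compound 4 (0.05 log units; within the scatter), so two quite different substitution patterns on the aryl ring arrive at the same level. Compound 1, with its 2-methoxyphenyl group, holds a limit and not a number, and the comparison gives an at least 3.0-fold lower number from compound 1 to compound 4 (0.48 log units; beyond the scatter), so a methoxy group as such does not tie a compound to that limit: the limit of > 50000 nM in this assay, at which 1 of the 4 values shown sits.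

Going by these compounds, whether the step to the 3,4-dimethoxyphenyl group needs both methoxy groups or only one of them stays open. On these data alone, what a carboxylic acid or an amine on this aryl ring would do to the number also stays open.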